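A few compounds are considered here, and "the series" means these few. Any claim that something is new, unique, unknown or untested is made for them only; others in the source may bear on it.

The shared core is the same throughout, and only the substituent on the thiocarbonyl side changes. Compound 1 `CN(C)C(=S)N/N=C/c1cc2cccnc2s1` carries a dimethylamino group there, and in a functional assay on HT-29 cells (Homo sapiens) for antiproliferative activity, read by sulforhodamine B assay, with a stated time of 72 h (on this read-out lower numbers stand for stronger inhibition and higher numbers for weaker inhibition), compound 1 gives 13400 nM. Compound 2 `FC(F)(F)c1ccccc1NC(=S)N/N=C/c1ccc2ccccc2n1` instead bears a phenyl ring with a trifluoromethyl group on the amide-type nitrogen, and in this assay compound 2 gives 18100 nM. Compound 3 `Fc1ccccc1NC(=S)N/N=C/c1ccc2ccccc2n1` is the fluoro analogue of compound 2. In this assay compound 3 reaches only the limit > 100000 nM, so no number is known for it. The single measured step, an at least 5.5-fold higher number from compound 2 to compound 3 (0.74 log units; beyond the scatter), therefore ends at the limit of > 100000 nM in this assay, at which 1 of the 3 values shown sits, and compound 3 stands there, at the weak end of everything shown.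

Compound 4 `N#Cc1ccc(NC(=S)N/N=C/c2ccc3ccccc3n2)cc1` has not been measured in this assay yet. It differs from compound 3 by 4-cyanophenyl in place of 2-fluorophenyl on an amide-type nitrogen. Among the compounds with values here, no measured step compares a cyano-bearing ring with a fluoro-bearing ring, so the size and direction of the change can only be bracketed: both aryl-substituted compounds lie in the weak range, and compound 4 is expected to stay there too. The expected step amounts to an at least 2.5-fold lower number from compound 3 to compound 4 (0.39 log units; beyond the scatter). For compound 4 the estimate in this assay is 40000 nM, with a range from 10000 nM to 150000 nM.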

Compound 4, half-maximal inhibitory concentration: 15600 nM
Compound 4: middle estimate off by 2.6-fold (0.41 log units), on the high side; measured number inside the range.
By their numbers in this assay, from the lowest: compounds 1, 4 and 2 (each within the scatter of the next). At a limit, above all of these: compound 3.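

Replacing 2-fluorophenyl with 4-cyanophenyl on the amide-type nitrogen gives an at least 6.4-fold lower number from compound 3 to compound 4 (0.80 log units; beyond the scatter), so the weak end reached by compound 3 is not shared by every substituted phenyl group at this place. In this assay compound 4 gives 15600 nM and compound 2 gives 18100 nM, values within the scatter of each other, which makes compound 3 the one aryl compound shown that goes against this shared range. The full size of the step stays unknown, since the value of compound 3 is a limit and not a number: the limit of > 100000 nM in this assay, at which 1 of the 4 values shown sits.

The change swaps both the substituent and its place on the phenyl ring, so the compounds shown cannot tell whether the nitrile itself or its place on the ring goes with the lower number. They also leave open how a methoxy group, an amine or a carboxylic acid on that ring would read out, and whether any aryl group here could reach a number clearly beyond the scatter of the dimethylamino compound 1.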